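Nitro on the 4-methoxyphenyl ring of compound 3

The compounds below may be only part of what the source reports. "The series", "measured", "known", "first", "only" and "open" are said of these compounds alone.

In a functional assay on SGC-7901 cells (Homo sapiens) for antiproliferative activity, read by MTT assay, with a stated time of 72 h (on this read-out lower numbers stand for stronger inhibition and higher numbers for weaker inhibition), compound 3 `CCOC(=O)c1cc(-c2ccc(OC)cc2)c(-c2cc(OC)c(OC)c(OC)c2)s1` gives 6820 nM and holds the lowest of the two true numbers in the set. Compound 1 `COc1ccc(-c2sc(C(=O)O)cc2-c2cc(OC)c(OC)c(OC)c2)cc1[N+](=O)[O-]` gives a higher number (23300 nM), and this gap lies beyond the scatter. Compound 2 `COc1ccc(-c2sccc2-c2cc(OC)c(OC)c(OC)c2)cc1OCc1ccccc1` reaches only a limit (> 100000 nM), so it is not a number and cannot be ranked with the other two.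

The next entry is compound 4 `CCOC(=O)c1cc(-c2ccc(OC)c([N+](=O)[O-])c2)c(-c2cc(OC)c(OC)c(OC)c2)s1`, which differs from compound 3 by nitro in place of hydrogen on an aromatic carbon with nitro in place of hydrogen on an aromatic carbon, ortho to a methoxy group. The same difference reads as 4-methoxyphenyl to 4-methoxy-3-nitrophenyl.

Among the measured compounds shown here, no measured pair in the set isolates this change, so the expectation rests on little. Compound 1 carries the 4-methoxy-3-nitrophenyl group and still gives a number (23300 nM), so compound 4 is also expected to give a number. No step beyond the scatter is expected in this assay, and the estimated change is a 1.2-fold lower number from compound 3 to compound 4 (0.09 log units; within the scatter) in size. For compound 4 the estimated value is 5500 nM with an expected range of 1500 nM to 22000 nM as its bounds.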

Compound 4, half-maximal inhibitory concentration: 19400 nM
Beside the measured number, compound 4's estimate is 3.5-fold (0.55 log units) below it, within the range that was stated.
By their numbers in this assay, from the lowest: compound 3; then compounds 4 and 1 (each within the scatter of the next). At a limit, above all of these: compound 2.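

Among the compounds shown here, on the aromatic carbon ortho to a methoxy group, nitro in place of hydrogen gives the first step that can be read: in this assay, the change brings a 2.8-fold higher number from compound 3 to compound 4 (0.45 log units; beyond the scatter), so with the ethyl ester held constant, this position responds to substitution and the added nitro weakens inhibition modestly. The ethyl ester compound 4 gives 19400 nM and the carboxylic acid compound 1 gives 23300 nM, and these two values lie within the scatter of each other, so with the 4-methoxy-3-nitrophenyl group in place, the two numbers do not separate. Nothing in the data at hand accounts for the step, which is reported here as an observation only.

On these data alone, whether the step belongs to nitro itself or would follow any group on this carbon remains open, and an amine or a fluorine at the same place would test that. Also open, as far as these compounds go, is whether the step keeps its size when the ethyl ester gives way to a longer chain, such as a butyl ester.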